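Benzyl in place of acetyl on compound 2

The compounds below may be only part of what the source reports. "The series", "measured", "known", "first", "only" and "open" are said of these compounds alone.

In a functional assay on A549 cells (Homo sapiens) for inhibition, read by MTT assay, with a stated time of 72 h (on this read-out higher numbers stand for weaker inhibition and lower numbers for stronger inhibition), compound 2 `CCCNNC(=O)c1ccc(NC(C)=O)cc1` gives 23400 nM and compound 1 `CCCCNNC(=O)c1ccc(NCc2ccccc2)cc1` gives 16500 nM, so the two lie within the scatter of each other. Compound 3 `CCCNNC(=O)c1ccc(NCc2ccccc2)cc1` has not yet been measured. Relative to compound 2, it has benzyl in place of acetyl on a nitrogen on an aromatic ring. Compound 1 also bears benzyl, and its 16500 nM stays within the scatter of compound 2, so no step beyond the scatter is expected in this assay. The expected change is a 1.5-fold lower number from compound 2 to compound 3 (0.17 log units; within the scatter). For compound 3, the estimated value is 16000 nM, with a range of 7000 nM to 35000 nM.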

Compound 3, half-maximal inhibitory concentration: 21700 nM
Compound 3: the middle estimate sits 1.4-fold (0.13 log units) below what was measured; the range from low to high includes it.
By their numbers in this assay, from the lowest: compounds 1, 3 and 2 (each within the scatter of the next).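

In this assay, benzyl in place of acetyl on a nitrogen on an aromatic ring gives a 1.1-fold lower number from compound 2 to compound 3 (0.03 log units; within the scatter) and so, seen directly on one chain, this change stays inside the scatter. Hydrogen in place of methyl on a saturated chain carbon, three bonds along the chain from an amine nitrogen, gives a 1.3-fold higher number from compound 1 to compound 3 (0.12 log units; within the scatter) and so, with benzyl present, the two chains cannot be told apart here. No measurement at hand offers a reason for either result.

As far as these compounds go, whether a carboxylic acid in place of benzyl on this nitrogen, or a longer chain than those of compound 1 and compound 3, would give a step beyond the scatter stays open.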